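The source may report more compounds than this note shows. Statements on the series, on what has been measured and on what is new or still open speak of the compounds shown alone.

Measured compounds:
- Compound 1, `COc1cc([C@H]2C[C@]2(CO)C(=O)Nc2ccccc2Cl)cc(OC)c1OC`: 40700 nM
- Compound 2, `CCOC(=O)C1(C(=O)NCc2ccccc2)CC1c1cc(OC)c(OC)c(OC)c1`: > 100000 nM; > 100000 nM (2 entries)
- Compound 3, `CCOC(=O)C1(C(=O)Nc2ccccc2[N+](=O)[O-])CC1c1cc(OC)c(OC)c(OC)c1`: 54100 nM; > 100000 nM (2 entries)

All three were tested in a functional assay on QGY cells (Homo sapiens) for cytotoxicity, read by MTT assay, with a stated time of 48 h; a higher number here means a weaker inhibitor, a lower number a stronger inhibitor. Among the compounds with values here, compound 1 gives 40700 nM, the only plain number among the three. Compound 2 returns only limits of the assay, > 100000 nM; > 100000 nM (2 entries), with no number at all. Compound 3 is mixed: its entries, (the several entries of compound 3 in this assay, 54100 nM; > 100000 nM (2 entries)), contain one number and two limits, so the same compound can fall either side of the edge of what this assay can report. Against that background compound 1 stands as the one compound with a single, settled value, and no two measured compounds differ in just one place, so no step between them can be read.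

Compound 4, `COc1cc([C@@H]2C[C@@]2(CO)C(=O)Nc2ccccc2Cl)cc(OC)c1OC`, is the next compound. Compared with compound 1, (the two compounds have the same atoms and bonds and differ only in configuration as drawn: 2 of 2 stereo elements differ (all stereocentres are inverted: mirror images); a stereocentre at a saturated ring carbon is drawn R in compound 1 and S in compound 4; a stereocentre at a saturated ring carbon is drawn S in compound 1 and R in compound 4). Within the data shown here, nothing among the measured compounds shows what a change of configuration alone does here, so the step in this assay from compound 1 to compound 4 could go either way; the expectation is a step of modest size, most likely within the scatter. The estimate for compound 4 is therefore 45000 nM, with a range from 15000 nM to 150000 nM, meaning an expected step of a 1.1-fold higher number from compound 1 to compound 4 (0.04 log units; within the scatter).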

Compound 4, half-maximal inhibitory concentration: 24500 nM
Compound 4: the middle estimate sits 1.8-fold (0.26 log units) above what was measured; the range from low to high includes it.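

Within the data shown here, compounds 1 and 4 form the first pair here that can be read as a single change, and that change is one of shape alone, since the two are mirror images with the same atoms and bonds: the fact that compounds 1 and 4 differ only in the configuration as drawn. In this assay, inverting both ring stereocentres together gives a 1.7-fold lower number from compound 1 to compound 4 (0.22 log units; within the scatter), so neither mirror image can be called the stronger inhibitor. For this pair, which carries a hydroxymethyl group and a chlorophenyl amide, the measured difference between the two drawn configurations is no larger than repeat measurements of the same compound would be expected to give.

No other pair among the compounds shown differs in just one place, so no other step can be read, and the effect of changing the ester, the amide group or the hydroxymethyl group on its own remains unknown. As far as these compounds go, it also remains open whether inverting only one of the two stereocentres would matter, or whether mirror images would separate further with a carboxylic acid or an amine in place of the hydroxymethyl group.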